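Oxazole-linked anilinopyrimidine series: aryl ether variation and microsomal stability

The compounds below may be only part of what the source reports. "The series", "measured", "known", "first", "only" and "open" are said of these compounds alone.

Measured compounds:
- compound 1 `C=CC(=O)NCc1coc(-c2c(N)ncnc2Nc2ccc(OCc3cccc(F)c3)c(Cl)c2)n1`: 0.483 h
- compound 2 `C=CC(=O)NCc1coc(-c2c(N)ncnc2Nc2ccc(Oc3ccccc3)c(Cl)c2)n1`: 0.983 h
- compound 3 `C=CC(=O)NCc1coc(-c2c(N)ncnc2Nc2ccc(Oc3ccc(F)cc3)c(Cl)c2)n1`: 1.1 h

In an in vitro ADME assay on microsomes from liver (Rattus norvegicus) for metabolic stability, tested at 5 uM (a higher number here means that the compound lasts longer, a lower number that the compound disappears faster), compound 3 gives the highest of the three numbers, though compound 2 with 0.983 h sits within the scatter of it; only compound 1 with 0.483 h is clearly apart. The two steps that separate compound 1 from the others, a 2.0-fold higher number from compound 1 to compound 2 (0.31 log units; beyond the scatter) and a 2.3-fold higher number from compound 1 to compound 3 (0.36 log units; beyond the scatter), are modest. The step of a 1.1-fold higher number from compound 2 to compound 3 (0.05 log units; within the scatter) is within the scatter.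

Compound 4 `C=CC(=O)NCc1coc(-c2c(N)ncnc2Nc2ccc(Oc3ccccn3)c(Cl)c2)n1` carries the change (pyridin-2-yl in place of 4-fluorophenyl on an oxygen on an aromatic ring). Among the compounds with values here, no measured step exchanges a carbon ring for one with a ring nitrogen, so nothing here bears directly on it. Within the data shown here, the only comparison that keeps the ether intact and alters the ring is the fluoro-for-hydrogen step from compound 2 to compound 3, which did not move the number beyond the scatter; the larger steps involved a change in the linker length, which compound 4 does not share.

Compound 4 is therefore expected to give roughly 1 h, with a range of 0.5 h to 2 h, meaning an expected step of a 1.1-fold lower number from compound 3 to compound 4 (0.04 log units; within the scatter), no direction beyond the scatter.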

Compound 4, half-life: 0.267 h
Estimate against measurement, compound 4: 3.7-fold (0.57 log units) above, outside the stated range (below it).
By their numbers in this assay, from the lowest: compounds 4 and 1 (each within the scatter of the next); then compounds 2 and 3 (each within the scatter of the next).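

In this assay the ring on the oxygen can move the number with the direct ether kept: pyridin-2-yl in place of 4-fluorophenyl gives a 4.1-fold lower number from compound 3 to compound 4 (0.61 log units; beyond the scatter) and pyridin-2-yl in place of phenyl gives a 3.7-fold lower number from compound 2 to compound 4 (0.57 log units; beyond the scatter) (both beyond the scatter, unlike the earlier fluoro-for-hydrogen step). Against the 3-fluorobenzyl group the exchange gives a 1.8-fold lower number from compound 1 to compound 4 (0.26 log units; within the scatter) (within the scatter), so the linker length is no longer the only change at this place that separates the compounds from compound 2 and compound 3. Nothing in hand accounts for the ring nitrogen's step.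

Open, going by these compounds, is whether the step is particular to pyridin-2-yl or also holds for pyridin-3-yl, pyridin-4-yl or pyrimidin-2-yl. Also open, on these data alone, is whether a fluoro on the pyridine ring would alter the number.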